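From compound 2 to its bromo analogue

A few compounds are considered here, and "the series" means these few. Any claim that something is new, unique, unknown or untested is made for them only; others in the source may bear on it.

In a functional assay on MCF7 cells (Homo sapiens) for inhibition (a lower number here means a stronger inhibitor, a higher number a weaker inhibitor), compound 1 (`COc1ccc(-c2nc3ccc(F)cc3o2)cc1`) gives 41000 nM, whereas compound 2 (`COc1ccc(-c2nc3cc(F)ccc3s2)cc1`) gives 490 nM, the lower of the two numbers by a margin beyond the scatter. Compound 3 (`COc1ccc(-c2nc3cc(F)ccc3s2)cc1Br`) differs from compound 2 by one change: bromo in place of hydrogen on an aromatic carbon, ortho to a methoxy group. Going by the values given here, no measured pair shows what this change does, so the expectation remains loose. A small gain in inhibition, possibly none beyond the scatter, is expected, with an estimated 1.6-fold lower number from compound 2 to compound 3 (0.21 log units; within the scatter). For compound 3 the estimated value is 300 nM, with an expected range of 50 nM to 2000 nM.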

Compound 3, half-maximal inhibitory concentration: 850 nM
The estimate for compound 3 lay 2.8-fold (0.45 log units) below the measured number; the range from low to high includes it.
By their numbers in this assay, from the lowest: compounds 2 and 3 (each within the scatter of the next); then compound 1.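

In this assay, bromo in place of hydrogen on an aromatic carbon, ortho to a methoxy group, gives a 1.7-fold higher number from compound 2 to compound 3 (0.24 log units; within the scatter) and so leaves compound 2 and compound 3 indistinguishable. Going by these compounds alone, this is the first measured reading at this position, and it shows that the bromo group, with its one heavy atom, is tolerated there. Nothing available bears on why this is so. Still open, from the compounds shown here alone, is what a group of another kind, such as an amine or a carboxylic acid, would do at this position. Also open, going by these compounds, is whether bromo would be tolerated elsewhere on this ring.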